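From furan-2-yl to trifluoromethyl on a shared core

The source may hold more compounds than are shown below. What is called first, only, known or untested is meant among the compounds shown, and "the series" means these compounds.

- Compound 1 `C#C[C@@]1(O)[C@@H](CO)O[C@@H](n2cc(Br)c3c(N)ncnc32)[C@@H]1O`: 93 nM
- Compound 2 `C#C[C@@]1(O)[C@@H](CO)O[C@@H](n2cc(I)c3c(N)ncnc32)[C@@H]1O`: 180 nM
- Compound 3 `C#C[C@@]1(O)[C@@H](CO)O[C@@H](n2cc(-c3ccco3)c3c(N)ncnc32)[C@@H]1O`: 14000 nM

In a functional assay on HeLa cells (Homo sapiens) for antiproliferative activity, read by cell counting, with a stated time of 72 h (on this read-out higher numbers stand for weaker inhibition and lower numbers for stronger inhibition), compound 3 has the highest number of the three, 14000 nM, so it inhibits most weakly. Compound 4 `C#C[C@@]1(O)[C@@H](CO)O[C@@H](n2cc(C(F)(F)F)c3c(N)ncnc32)[C@@H]1O` carries one change: trifluoromethyl in place of furan-2-yl on an aromatic carbon.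

Bromo and iodo sit within the scatter of each other, a 1.9-fold higher number from compound 1 to compound 2 (0.29 log units; within the scatter). Furan-2-yl in their place gave two large steps, a 150-fold higher number from compound 1 to compound 3 (2.18 log units; beyond the scatter) and a 78-fold higher number from compound 2 to compound 3 (1.89 log units; beyond the scatter). Going by the values given here, no trifluoromethyl compound has been measured, so these steps serve only as a rough guide. A large step downward is expected, a 35-fold lower number from compound 3 to compound 4 (1.54 log units; beyond the scatter), somewhat smaller than those two. For compound 4, the estimated value is 400 nM, with an expected range of 60 nM to 3000 nM.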

Compound 4, half-maximal inhibitory concentration: 750 nM
Compound 4: the middle estimate sits 1.9-fold (0.27 log units) below what was measured, within the range that was stated.
By their numbers in this assay, from the lowest: compounds 1 and 2 (each within the scatter of the next); then compound 4; then compound 3.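

In this assay, a group without a ring at this position recovers much of what furan-2-yl lost (a 19-fold lower number from compound 3 to compound 4 (1.27 log units; beyond the scatter)). Trifluoromethyl still falls short of both halogens (a 4.2-fold higher number from compound 2 to compound 4 (0.62 log units; beyond the scatter); an 8.1-fold higher number from compound 1 to compound 4 (0.91 log units; beyond the scatter)), so this position separates a group that bromo and iodo, level with each other, could not: lacking a ring is not enough to match them. Nothing available explains these differences. As far as these compounds go, whether a methyl, a nitrile or an amine here would sit with the halogens or with trifluoromethyl remains open.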